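The source may hold more compounds than are shown below. What is called first, only, known or untested is meant among the compounds shown, and "the series" means these compounds.

Measured in a functional assay on HepG2 cells (Homo sapiens) for inhibition, read by MTT assay, with a stated time of 72 h; a higher number here means a weaker inhibitor, a lower number a stronger inhibitor:
- Compound 1 `CCCc1ccc(NC(=O)C2CCN(C/C=C/c3ccccc3)CC2)cc1`: 9410 nM
- Compound 2 `CCCCc1ccc(NC(=O)C2CCN(C/C=C/c3ccccc3)CC2)cc1`: 4320 nM

In this assay, compound 1 gives 9410 nM, the higher of the two numbers. Compound 3 `O=C(Nc1cccc(F)c1)C1CCN(C/C=C/c2ccccc2)CC1` differs from it as follows: 3-fluorophenyl in place of 4-propylphenyl on an amide-type nitrogen. That is, 3-fluorophenyl stands in place of 4-propylphenyl on an amide-type nitrogen. For the measured compounds named here, only one measured step bears on this, a 2.2-fold lower number from compound 1 to compound 2 (0.34 log units; beyond the scatter), which comes from methyl in place of hydrogen on a saturated chain carbon. Going by the values given here, no measured compound carries 3-fluorophenyl, so the guide is weak. A modest rise is expected, estimated as a 1.5-fold higher number from compound 1 to compound 3 (0.17 log units; within the scatter). For compound 3 the estimate is 14000 nM, with a range of 5000 nM to 40000 nM.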

Compound 3, half-maximal inhibitory concentration: 51100 nM
Compound 3: the middle estimate sits 3.7-fold (0.56 log units) below what was measured, outside the stated range (above it).
By their numbers in this assay, from the lowest: compound 2; then compound 1; then compound 3.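

In this assay, exchanging 4-propylphenyl for 3-fluorophenyl on the amide-type nitrogen gives a 5.4-fold higher number from compound 1 to compound 3 (0.73 log units; beyond the scatter) in a single change. Compound 1 and compound 2 had shown only a change in chain length, whereas this step shows that replacing the whole aryl group also moves the number beyond the scatter. No evidence is available to explain this rise. Because the propyl chain leaves as fluorine enters, the compounds shown cannot separate the two contributions. From the compounds shown here alone, it also remains open how a plain phenyl, or a phenyl carrying a methoxy group or a pentyl chain, would read.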